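The source may report more compounds than this note shows. Statements on the series, on what has been measured and on what is new or still open speak of the compounds shown alone.

Three analogues that share one core have been examined in a functional assay on MCF cells (Homo sapiens) for antiproliferative activity, with a stated time of 72 h; on this read-out higher numbers stand for weaker inhibition and lower numbers for stronger inhibition. Compound 1 `OC[C@H]1O[C@@H](n2cnc3c(NCc4cccc(Br)c4)ncnc32)[C@H](O)[C@@H]1O` is reported in this assay only as a limit, > 166000 nM. Compound 2 `COc1cccc(CNc2ncnc3c2ncn3[C@@H]2O[C@H](CO)[C@@H](O)[C@H]2O)c1` likewise reaches only the limit in this assay, > 166000 nM. Going by the values given here, the single one-place step, methoxy in place of bromo on an aromatic carbon, therefore gives a step that the two limits leave unreadable from compound 1 to compound 2, with both ends at the limit of > 166000 nM in this assay, at which 2 of the 3 values shown sit. Among the compounds with values here, compound 3 `COc1ccc(CNc2ncnc3c2ncn3C2OC(CO)[C@@H](O)[C@H]2O)c(O)c1` is the one member with a number in this assay, 2200 nM. Within the data shown here, compound 2 thus stands at the limit, and no measured step of readable size leads to it or away from it.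

Compound 4 `OC[C@H]1O[C@@H](n2cnc3c(NCc4cccc(O)c4O)ncnc32)[C@H](O)[C@@H]1O` is the unmeasured member. It differs from compound 2 by 2,3-dihydroxyphenyl in place of 3-methoxyphenyl on a saturated chain carbon bound to a nitrogen on an aromatic ring. Among the measured compounds shown here, only the step from compound 1 to compound 2 bears on a change in this one place, and its size cannot be read. Compound 3 shows that a ring carrying hydroxy on the same saturated chain carbon can return a measured number in this assay, but compound 3 is not one step from compound 2 or from compound 4. On this thin ground a step toward stronger inhibition is expected, an at least 5.5-fold lower number from compound 2 to compound 4 (0.74 log units; beyond the scatter), with wide uncertainty and a real chance that compound 4 again returns only a limit. Compound 4 is estimated at 30000 nM in this assay, within 3000 nM to 166000 nM.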

Compound 4, half-maximal inhibitory concentration: 5200 nM
Compound 4: the middle estimate sits 5.8-fold (0.76 log units) above what was measured; the measured number falls inside the stated range.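

In this assay, the place on a saturated chain carbon bound to a nitrogen on an aromatic ring now proves able to move the read-out: 2,3-dihydroxyphenyl in place of 3-methoxyphenyl gives an at least 31-fold lower number from compound 2 to compound 4 (1.50 log units; beyond the scatter), and the same group in place of 3-bromophenyl gives an at least 31-fold lower number from compound 1 to compound 4 (1.50 log units; beyond the scatter). The earlier step at this place, between the bromo and methoxy rings, could not be read, so the position had shown no change of any readable size; a single change here is now seen to be enough to bring the series off the limit. Both new sizes are only lower bounds rather than measured gaps, because compound 1 and compound 2 each stand at a limit: the limit of > 166000 nM in this assay, at which 2 of the 4 values shown sit.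

The compounds shown leave open whether both hydroxy groups of compound 4 are needed or one alone would give a comparable number. They also leave open whether an amine or a carboxylic acid on the phenyl ring in place of the hydroxy groups would return a number in this assay.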